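The compounds below may be only part of what the source reports. "The series", "measured", "known", "first", "only" and "open" are said of these compounds alone.

Measured so far in an in vivo ADME assay on the whole organism for pharmacokinetics, with Canis familiaris (Canis lupus familiaris) as the target, at a dose of 0.6 mg/kg by the oral route; on this read-out lower numbers stand for lower oral bioavailability and higher numbers for higher oral bioavailability:
compound 1, `CC[C@H](C)[C@@H]1C(=O)N[C@H](C2Cc3ccccc3C2)C(=O)N1[C@@H](C(=O)N(C)C)c1ccc(C)[n+]([O-])c1`, gives 11%
compound 2, `CC[C@H](C)[C@@H]1C(=O)N[C@H](C2Cc3ccccc3C2)C(=O)N1[C@@H](C(=O)N(C)C)c1ccc(C)nc1C`, gives 44%
compound 3, `CC[C@H](C)[C@@H]1C(=O)N[C@H](C2Cc3ccccc3C2)C(=O)N1[C@@H](C(=O)N1CCOCC1)c1ccc(C)nc1`, gives 14%

Within this set compound 3 holds the second highest number of the three. Its nearest neighbour is compound 1, lower by an amount that lies within the scatter, so the two are not told apart; compound 2 stands far above it, beyond the scatter. Going by the values given here, the only single-point step measured so far is a number 33 percentage points higher from compound 1 to compound 2 (beyond the scatter), a change of the aromatic ring on the chain carbon bound to the ring nitrogen and the carbonyl carbon.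

Compound 4, `CC[C@@H](C)[C@@H]1C(=O)N[C@H](C2Cc3ccccc3C2)C(=O)N1[C@@H](C(=O)N1CCOCC1)c1ccc(C)nc1`, is now to be measured in this assay. Against compound 3 the change is: the two compounds have the same atoms and bonds and differ only in configuration as drawn: 1 of 4 stereo elements differ; a stereocentre at a saturated chain carbon is drawn S in compound 3 and R in compound 4

Among the compounds with values here, no measured step bears on this change: the one step on record concerns an exchange of aromatic groups and says nothing about configuration at the saturated chain carbon. Within the data shown here, with no comparable pair in hand, no direction is supported, and the working expectation is a step within the scatter, no change at the digits printed from compound 3 to compound 4 (within the scatter), acknowledged as unsupported by data. Compound 4 is therefore estimated at 14%, with a range from 5% to 30%.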

Compound 4, oral bioavailability: 31%
Estimate against measurement, compound 4: 17 percentage points below; measured number above the stated range.
By their numbers in this assay, from the lowest: compounds 1 and 3 (each within the scatter of the next); then compound 4; then compound 2.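

In this assay, the configuration at this saturated chain carbon is not a silent detail of the series: a number 17 percentage points higher from compound 3 to compound 4 (beyond the scatter). Going by these compounds alone, this is the first step on record at this stereocentre, and it shows that inversion from S to R, with every atom and bond retained, can move oral bioavailability beyond the scatter, whereas the only earlier step involved an exchange of aromatic groups. The step can be assigned to this inversion alone because nothing else separates the pair: the fact that compounds 3 and 4 differ only in the configuration as drawn

The compounds shown do not tell whether the same inversion gives a step of similar direction or size with the dimethylamide of compound 1 or compound 2, or with the aromatic groups these compounds carry, and they do not show which part of oral exposure in the dog responds to the change. Also open, going by these compounds, is what happens when the branched chain holding this stereocentre gives way to a group with no stereocentre there, such as a cyclohexyl ring or an unbranched longer chain.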